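This account rests on a few compounds, and the source may have more. Where it says the series, first, only, none or still open, it means among the compounds named here.

Measured compounds:
- compound 1, `CCCCCCNC(=O)CN1CC(=O)N(C)[C@@H](Cc2ccc(-c3cc(OC)c(OC)c(OC)c3)cc2)C1=O`: 3 nM in a functional assay for agonist activity at follicle-stimulating hormone receptor (Homo sapiens), read by a luciferase reporter; on this read-out higher numbers stand for an effect only at larger amounts of compound and lower numbers for an effect already at smaller amounts
- compound 2, `CCCCCCCCCN1CC(=O)N(C)[C@@H](Cc2ccc(-c3cc(OC)c(OC)c(OC)c3)cc2)C1=O`: 900 nM

Within the data shown here, compound 2 gives the highest of the two numbers in this assay; the only neighbour is compound 1, and the move between them is a 300-fold higher number from compound 1 to compound 2 (2.48 log units; beyond the scatter). Compound 3, `CCCCCCN1CC(=O)N(C)[C@@H](Cc2ccc(-c3cc(OC)c(OC)c(OC)c3)cc2)C1=O`, has not yet been measured. It differs from compound 2 by hydrogen in place of propyl on a saturated chain carbon, six bonds along the chain from an amide-type nitrogen in a ring, that is, the nonyl chain on the ring nitrogen is shortened to hexyl. Among the measured compounds shown here, no measured step shortens a plain chain; the one available step, a 300-fold higher number from compound 1 to compound 2 (2.48 log units; beyond the scatter), exchanges an amide-bearing chain for a plain one and so does not directly bear on this change. The expectation therefore rests on compound 2 alone, with no firm direction: an expected step of a 1.3-fold higher number from compound 2 to compound 3 (0.12 log units; within the scatter), within the scatter, is the best that can be said. Compound 3 is estimated at 1200 nM, with a range of 250 nM to 6000 nM.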

Compound 3, half-maximal effective concentration: 3000 nM
Beside the measured number, compound 3's estimate is 2.5-fold (0.40 log units) below it; the range from low to high includes it.
By their numbers in this assay, from the lowest: compound 1; then compound 2; then compound 3.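

In this assay, shortening the plain chain on the ring nitrogen from nonyl to hexyl has a measurable effect (a 3.3-fold higher number from compound 2 to compound 3 (0.52 log units; beyond the scatter)), so the length of a plain chain matters at this position, with the longer chain needing less compound. Even so, that step is small beside the gap between the hexylcarbamoyl-bearing chain and the plain hexyl chain (a 1000-fold higher number from compound 1 to compound 3 (3.00 log units; beyond the scatter)), and the nonyl chain of compound 2 closes only a little of that gap. Nothing available here explains either difference.

Two plain chains cannot show whether the trend continues with a chain longer than nonyl or reverses. Going by these compounds, it also remains open whether an ester or ether in the chain, or a terminal amine or carboxylic acid, could stand in for the amide.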